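Compound 1 to compound 3: carbamoyl replaced

A few compounds are considered here, and "the series" means these few. Any claim that something is new, unique, unknown or untested is made for them only; others in the source may bear on it.

Measured values (an ADME assay on BJ cells (Homo sapiens) for cytotoxicity, with a stated time of 72 h; a lower number here means that less compound is needed, a higher number that more compound is needed for the effect):
- compound 1 (`Cc1cc(NC(=O)Nc2cccc(C(N)=O)c2)c2ccccc2n1`): > 25000 nM (a limit)
- compound 2 (`Cc1cc(NC(=O)Nc2ccc(N(C)C)cc2)c2ccccc2n1`): > 25000 nM (a limit)

Compound 1 stands only at a limit, not at a number (> 25000 nM). The whole data set so far is summed up as (the limit of > 25000 nM in this assay, at which 2 of the 2 values shown sit). Compound 3 (`Cc1cc(NC(=O)Nc2cccc(OC(F)(F)F)c2)c2ccccc2n1`) carries trifluoromethoxy in place of carbamoyl on an aromatic carbon, meta to a large group (trifluoromethoxy in place of carbamoyl on an aromatic carbon). Within the data shown here, no measured step is available for sizing this change. A modest move towards a lower number in this assay is expected, possibly none beyond the scatter. The expected step is small (an at least 1.2-fold lower number from compound 1 to compound 3 (0.09 log units; that floor lies within the scatter)). For compound 3 the estimated value is 20000 nM with an expected range (8000 nM to 25000 nM).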

Compound 3, half-maximal effective concentration: 25000 nM
Estimate against measurement, compound 3: 1.3-fold (0.10 log units) below, and the stated range covers the measured number.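

In this assay compound 3 gives 25000 nM, the only actual number among the compounds shown. Compound 1 stands at a limit, > 25000 nM, so the size of the step at this aromatic carbon cannot be read. Trifluoromethoxy in place of carbamoyl therefore yields a measurable value, but the data set remains dominated by a single limit: the limit of > 25000 nM in this assay, at which 2 of the 3 values shown sit.

Going by these compounds, the change gives a number no higher from compound 1 to compound 3 (the limit leaves the size open), and it remains open whether any group at this carbon gives a number well under the one now measured. A carboxylic acid or an amine there would test this, and neither is among the compounds shown.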